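The source may hold more compounds than are shown below. What is called first, only, known or untested is meant among the compounds shown, and "the series" means these compounds.

Measured in a functional assay on MCF7 cells (Homo sapiens) for antiproliferative activity, read by MTT assay; a higher number here means a weaker inhibitor, a lower number a stronger inhibitor:
Compound 1 `COc1cc2c(Oc3ccc(NC(=O)Nc4ccccc4Cl)cc3)ccnc2cc1OCCCCCCC(=O)NO`: 2780 nM
Compound 2 `COc1cc2c(Oc3ccc(NC(=O)Nc4ccccc4F)cc3)ccnc2cc1OCCCCCCC(=O)NO`: 660 nM

Compound 2 stands lowest of the two and is therefore the stronger inhibitor in this assay. Compound 3 `COc1cc2c(Oc3ccc(NC(=O)Nc4ccc(C)cc4C)cc3)ccnc2cc1OCCCCCCC(=O)NO` has not yet been measured. It differs from compound 2 as follows: 2,4-dimethylphenyl in place of 2-fluorophenyl on an amide-type nitrogen. In short, 2,4-dimethylphenyl replaces 2-fluorophenyl on an amide-type nitrogen. For the measured compounds named here, the one measured step that bears on this is a 4.2-fold lower number from compound 1 to compound 2 (0.62 log units; beyond the scatter), with fluoro in place of chloro on an aromatic carbon. That step is modest but beyond the scatter, and it shows that this group can shift the number. Going by the values given here, no compound carrying methyl groups has been measured, so the direction is uncertain. A modest rise of similar size is expected, and the estimated step is a 2.3-fold higher number from compound 2 to compound 3 (0.36 log units; beyond the scatter). For compound 3 the estimate is 1500 nM, with an expected range of 500 nM to 4500 nM.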

Compound 3, half-maximal inhibitory concentration: 3430 nM
Beside the measured number, compound 3's estimate is 2.3-fold (0.36 log units) below it; low and high end bracket the measured number.
By their numbers in this assay, from the lowest: compound 2; then compounds 1 and 3 (each within the scatter of the next).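

Replacing 2-fluorophenyl with 2,4-dimethylphenyl on the amide-type nitrogen gives a 5.2-fold higher number from compound 2 to compound 3 (0.72 log units; beyond the scatter) in this assay, so a group carrying no halogen can also raise the number at this position. Against the chloro-bearing compound, the same group gives a 1.2-fold higher number from compound 1 to compound 3 (0.09 log units; within the scatter), which puts compounds 1 and 3 level and leaves compound 2, with its 2-fluorophenyl group, as the strongest inhibitor of the three. Nothing available explains why the fluoro-bearing ring stands apart from the other two.

As far as these compounds go, whether a plain phenyl or a 2-methylphenyl group would stand with compound 2 or with compounds 1 and 3 remains open. From the compounds shown here alone, it is also open whether the shift from compound 2 to compound 3 comes from losing the fluoro group or from gaining either methyl group.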